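The compounds below may be only part of what the source reports. "The series", "measured", "known", "first", "only" and "open" are said of these compounds alone.

Measured so far in an assay on isolated protein for inhibition of DNA topoisomerase 1 (Homo sapiens), tested at 100 uM; a higher number here means a stronger effect of the compound at the concentration tested, a lower number a weaker effect:
- compound 1, `Clc1cccc(-c2cc(-c3ccc(Cl)o3)cc(-c3cccs3)n2)c1`: compound 1 gives 42%
- compound 2, `Clc1ccc(-c2cc(-c3ccc(Cl)o3)cc(-c3cccs3)n2)cc1`: compound 2 gives 38.9%
- compound 3, `Cc1ccc(-c2cc(-c3ccc(Cl)o3)cc(-c3ccsc3)n2)o1`: compound 3 gives 9.1%

Compound 3 stands lowest of the three numbers in this assay; its gap to compound 2, the nearest, and to compound 1, the furthest, lies beyond the scatter in both cases. Compound 4, `Cc1ccccc1-c1cc(-c2ccc(Cl)o2)cc(-c2ccsc2)n1`, is not yet measured. It differs from compound 3 at one place: 2-methylphenyl in place of 5-methylfuran-2-yl on an aromatic carbon.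

The only measured step among these compounds is a number 3.1 percentage points lower from compound 1 to compound 2 (within the scatter). It concerns a different position and a different pair of groups, so it bears on the present change only in showing that exchanging one chlorophenyl group for another left this read-out essentially unchanged. Nothing measured relates a methylfuranyl group to a methylphenyl group at the position in question. For the measured compounds named here, compounds 1 and 2, which carry a chlorophenyl group where compound 3 carries 5-methylfuran-2-yl, give higher numbers, but they also differ from compound 3 elsewhere, so no single step can be drawn from them. The step is therefore estimated as a number 8.9 percentage points higher from compound 3 to compound 4 (within the scatter), a moderate rise with wide uncertainty. For compound 4 the expected value in this assay is 18%, in the range 4% to 38%.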

Compound 4, a percentage reported as inhibition, at one concentration (the size of the read-out at that concentration, not a potency): 6.7%
The estimate for compound 4 lay 11.3 percentage points above the measured number; measured number inside the range.
By their numbers in this assay, from the lowest: compounds 4 and 3 (each within the scatter of the next); then compounds 2 and 1 (each within the scatter of the next).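

In this assay, placing 2-methylphenyl instead of 5-methylfuran-2-yl on the aromatic carbon next to the ring nitrogen gives a number 2.4 percentage points lower from compound 3 to compound 4 (within the scatter), so this exchange leaves the two compounds indistinguishable in this read-out. For the compounds shown here, this is the first measured step at this position, and it holds with the 5-chlorofuran-2-yl and thiophen-3-yl groups unchanged: a five-membered aromatic ring with 1 hetero atom and 1 hydrogen-bond acceptor gives way to a six-membered aromatic ring of carbon only with 0 hydrogen-bond acceptors, without a separation beyond the scatter. The available data offer no explanation for this outcome.

Compounds 1 and 2 differ from compounds 3 and 4 both in the group at this position and in how the thiophene is attached, so the contribution of each of these two differences remains unresolved. Also open, on these data alone, is whether a group of a different kind at this position, such as an amine, a carboxylic acid or a longer alkyl chain, would separate from 5-methylfuran-2-yl and 2-methylphenyl in this read-out.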